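The source may report more compounds than this note shows. Statements on the series, on what has been measured and on what is new or still open speak of the compounds shown alone.

In an in vivo ADME assay on the whole organism (strain C57) for pharmacokinetics, with Mus musculus as the target, at a dose of 2 mg/kg by the intravenous route (on this read-out higher numbers stand for fast clearance and lower numbers for slow clearance), compound 1 `Cn1c(-c2ccccc2C(F)(F)F)nnc1C12CCC(CCCC(C)(F)F)(CC1)CC2` gives 14 mL/min/kg and compound 2 `CCCCCC12CCC(c3nnc(-c4ccccc4C(F)(F)F)n3C)(CC1)CC2` gives 273 mL/min/kg as the higher of the two numbers. The measured step of a 20-fold higher number from compound 1 to compound 2 (1.29 log units; beyond the scatter) comes with ethyl in place of 1,1-difluoroethyl and is large, well beyond the usual scatter.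

Compound 3 `CC(O)CCCC12CCC(c3nnc(-c4ccccc4C(F)(F)F)n3C)(CC1)CC2` has not been measured yet. Its difference from compound 2 is hydroxy in place of hydrogen on a saturated chain carbon bound to two saturated chain carbons and amounts to hydroxy in place of hydrogen on a saturated chain carbon bound to two saturated chain carbons, which can also be read as ethyl to 1-hydroxyethyl. For the measured compounds named here, that reading concerns the same ethyl end of the chain as the measured step, so this step is the only guide. Going by the values given here, compound 1 at 14 mL/min/kg shows that a change there can go with a much lower number, but it carries fluorine, and no hydroxy compound has been measured. Only part of that step is therefore expected to carry over, in the same downward direction. The expected move a 3.9-fold lower number from compound 2 to compound 3 (0.59 log units; beyond the scatter) is a clear fall but a smaller one than the large step already described. Compound 3 is estimated at 70 mL/min/kg with an expected range from 20 mL/min/kg to 200 mL/min/kg on this basis.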

Compound 3, clearance: 88 mL/min/kg
Compound 3: middle estimate off by 1.3-fold (0.10 log units), on the low side, and the stated range covers the measured number.
By their numbers in this assay, from the lowest: compound 1; then compound 3; then compound 2.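

In this assay, for the compounds shown here, placing hydroxy in place of hydrogen on a saturated chain carbon bound to two saturated chain carbons gives a 3.1-fold lower number from compound 2 to compound 3 (0.49 log units; beyond the scatter), a modest step but one beyond the scatter, so fluorine is not the only change at this end of the chain that goes with a lower number. The 1-hydroxyethyl end does not match the 1,1-difluoroethyl end, however: replacing the latter with the former gives a 6.3-fold higher number from compound 1 to compound 3 (0.80 log units; beyond the scatter), also modest and beyond the scatter, which leaves compound 1 with the lowest number of the three and places compound 3 clearly between the other two. There is no measurement here that explains why these groups differ in this way.

The compounds shown leave open whether a single fluorine, a ketone carbonyl or an amine at this end of the chain would fall nearer to compound 1 or to compound 2. They also leave open whether hydroxy would be followed by a similar step if it stood on a longer chain.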